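The source may hold more compounds than are shown below. What is called first, only, known or untested is meant among the compounds shown, and "the series" means these compounds.

Measured in a functional assay on HL-60 cells (Homo sapiens) for antiproliferative activity, read by MTT assay; on this read-out lower numbers stand for stronger inhibition and higher numbers for weaker inhibition:
- compound 1 (`CCC[C@@H]1O[C@H](COCc2ccccc2)[C@@H](OCc2ccccc2)[C@H](OCc2ccccc2)[C@H]1O`): 11700 nM
- compound 2 (`CCC[C@H]1O[C@H](COCc2ccccc2)[C@@H](OCc2ccccc2)[C@H](OCc2ccccc2)[C@@H]1O`): "not active" (no number reported)
- compound 3 (`CCC[C@H]1O[C@H](COCc2ccccc2)[C@H](OCc2ccccc2)[C@H](OCc2ccccc2)[C@H]1O`): "not active" (no number reported)

Compound 3 carries no number ("not active" (no number reported)) and sits with compound 2 on that result. Only compound 1 gives a figure (11700 nM), and what separates it from compound 3 is the fact that compounds 1 and 3 differ only in the configuration as drawn alone.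

Compound 4 (`CCC[C@@H]1O[C@H](COCc2ccccc2)[C@H](OCc2ccccc2)[C@H](OCc2ccccc2)[C@H]1O`) has not yet been measured. The change is the two compounds have the same atoms and bonds and differ only in configuration as drawn: 1 of 5 stereo elements differ; a stereocentre at a saturated ring carbon is drawn R in compound 3 and S in compound 4: a stereocentre at a saturated ring carbon goes from drawn R to drawn S, and nothing leaves or enters.

Going by the values given here, no measured step covers this kind of change, so the size of the step in this assay can only be expected loosely. From compound 3 ("not active" (no number reported)) the only possible direction is toward stronger inhibition, and any gain is expected to stay modest, since the one figure in the series belongs to compound 1 (11700 nM). A result with no number is expected to be the more likely outcome. If a number is reported, compound 4 is estimated at 30000 nM (expected range 10000 nM to 100000 nM).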

Compound 4, half-maximal inhibitory concentration: "not active" (no number reported)
Nothing numeric was reported for compound 4, and the estimate cannot be compared.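

Compound 3 and compound 4 both come back without a number in this assay, so no step can be read between them. It remains open which configuration in the series, if any single one, accounts for the only figure, that of compound 1 at 11700 nM.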